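A few compounds are considered here, and "the series" means these few. Any claim that something is new, unique, unknown or untested is made for them only; others in the source may bear on it.

Of the compounds shown here, three have been measured so far. Compound 1, with the structure `CCN(Cc1cccs1)C(=O)COc1ccc(F)cc1`, gives 422 nM in an assay on HEK293 cells for agonist activity at transient receptor potential cation channel subfamily M member 8 (Homo sapiens), read by fluorescence and calcium flux, with a stated time of 15 min; on this read-out higher numbers stand for an effect only at larger amounts of compound and lower numbers for an effect already at smaller amounts. Compound 2, with the structure `CCN(Cc1cccs1)C(=O)c1cc2cc(C)ccc2o1`, gives 120 nM in this assay. Compound 3, with the structure `CON(Cc1cccs1)C(=O)COc1ccc(C)cc1`, gives 10 nM in this assay and thus stands lowest of the three; its gap to compound 2 and its larger gap to compound 1 both lie beyond the scatter of repeated measurements, so compound 3 is the most potent of the set. Compound 3 differs from the other two in more than one place. For the measured compounds named here, no single measured step leads to it.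

The next compound, compound 4, has the structure `C=CCN(Cc1cccs1)C(=O)COc1ccc(C)cc1`. It differs from compound 3 in one place: allyl in place of methoxy on an amide-type nitrogen. Whether an allyl group on that nitrogen serves as well as a methoxy group cannot be read from any measured pair here, so the expectation rests on the fact that the methoxy compound 3 is the most potent member. A moderate loss is expected, with the step from compound 3 to compound 4 in this assay estimated at a 3.0-fold higher number from compound 3 to compound 4 (0.48 log units; beyond the scatter). Compound 4 is therefore expected to give about 30 nM in this assay, within a range from 8 nM to 120 nM.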

Compound 4, half-maximal effective concentration: 20 nM
Compound 4: the middle estimate sits 1.5-fold (0.18 log units) above what was measured; measured number inside the range.
By their numbers in this assay, from the lowest: compounds 3 and 4 (each within the scatter of the next); then compound 2; then compound 1.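

In this assay, allyl in place of methoxy on the amide-type nitrogen gives a 2.0-fold higher number from compound 3 to compound 4 (0.30 log units; within the scatter), so this pair does not separate the two groups. For the compounds shown here, this is the first measured pair that differs in one place, and it shows that the oxygen of methoxy, with its hydrogen-bond acceptor, is not required on this nitrogen for a value in this range: allyl has neither, and it brings a double bond instead. The data offer no measurement that explains why these two different groups give matching results.

Still open, from the compounds shown here alone, is how a longer chain such as butyl, or a chain ending in a hydroxyl group or an amine, would behave on this nitrogen, and so how much room the position allows. Also open, going by these compounds, is whether allyl and methoxy would match on a different core, such as the core of compound 2, since this single pair speaks only for the core shared by compound 3 and compound 4.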